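Extending the ester-side chain in the shared core series

The source may report more compounds than this note shows. Statements on the series, on what has been measured and on what is new or still open speak of the compounds shown alone.

Going by the values given here, compound 2 `CCCCCCCCCCOC(=O)CCC(=O)N1CCN(CCCOc2cc3c(Nc4ccc(F)c(Cl)c4)ncnc3cc2OC)CC1` holds the higher of the two numbers so far, giving 95.7% in a functional assay on A549 cells (Homo sapiens) for cytotoxicity, read by MTT assay, with a stated time of 24 h, tested at 10 uM; on this read-out higher numbers stand for a weaker effect at the one concentration tested and lower numbers for a stronger effect; its only neighbour is compound 1 `CCCCOC(=O)CCC(=O)N1CCN(CCCOc2cc3c(Nc4ccc(F)c(Cl)c4)ncnc3cc2OC)CC1`, which gives 94.4%, and the two values lie within the scatter of each other. Compound 3 `CCCCCCCCCCCCCCCCCCCCOC(=O)CCC(=O)N1CCN(CCCOc2cc3c(Nc4ccc(F)c(Cl)c4)ncnc3cc2OC)CC1` is the next member to be measured. Its difference from compound 2 is decyl in place of hydrogen on a saturated chain carbon, ten or more bonds along the chain from an oxygen next to a carbonyl group. Among the compounds with values here, the one measured step that bears on this change is a number 1.3 percentage points higher from compound 1 to compound 2 (within the scatter), a chain extension of the same kind, and it stayed within the scatter. On that basis no step beyond the scatter is expected from compound 2 to compound 3 in this assay, and the expected step is a number 0.7 percentage points lower from compound 2 to compound 3 (within the scatter). Within the data shown here, compound 3 is accordingly estimated at 95%, with a range from 84% to 103%; a larger shift would go against the single step seen so far.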

Compound 3, a percentage reported as activity, at one concentration (the size of the read-out at that concentration, not a potency): 94%
For compound 3 the middle estimate is 1 percentage points above the measured one; the measured number falls inside the stated range.
By their numbers in this assay, from the lowest: compounds 3, 1 and 2 (each within the scatter of the next).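

In this assay the decyl extension gives a number 1.7 percentage points lower from compound 2 to compound 3 (within the scatter), so a second lengthening of the alkyl chain on the ester side also stays within the scatter. The flat picture across compound 1, compound 2 and compound 3 now rests on two steps rather than one. The data shown offer no measurement that would explain this flat result.

Open is whether a chain ending in an amine or a carboxylic acid at this place would read differently from the plain alkyl chains shown. Also open, on these data alone, is whether a short ester such as methyl would stay within the scatter of compound 1.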